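The compounds below may be only part of what the source reports. "The series", "measured", "known", "first", "only" and "open" are said of these compounds alone.

The compounds here were tested in an ADME assay on MT4 cells (Homo sapiens) for cytotoxicity, read by MTT assay, with a stated time of 96 h; a lower number here means that less compound is tolerated, a higher number that more compound is tolerated. Compound 1 `Cc1ccc(NCc2cn(-c3ccccc3)nc2-c2ccccc2)cc1` gives > 100000 nM, which is a limit of the assay and not a number. Compound 2 `Brc1ccc(NCc2cn(-c3ccccc3)nc2-c2ccc(Br)cc2)cc1` gives > 100000 nM, which is also a limit and not a number. Within the data shown here, compound 2 therefore has no exact reading, and it shares its place with the only other compound measured: the limit of > 100000 nM in this assay, at which 2 of the 2 values shown sit.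

Compound 3 `Cc1ccc(NCc2cn(-c3ccccc3)nc2-c2ccc(Br)cc2)cc1` changes one spot of compound 2, with methyl in place of bromo on an aromatic carbon, so that (4-bromophenyl)amino becomes (4-methylphenyl)amino (methyl in place of bromo on an aromatic carbon). The swap sits on a six-membered aromatic ring of carbon only, para to a large group.

Among the measured compounds shown here, no measured pair shows what such a swap does in this assay. The expectation has to start from compound 2 at > 100000 nM, which is a limit. The estimated step of a number no higher from compound 2 to compound 3 (the limit leaves the size open) is none beyond the usual scatter, in either direction. For compound 3 the expected half-maximal cytotoxic concentration is 100000 nM, with an estimated range of 50000 nM to 200000 nM, and the assay may well report only a limit again.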

Compound 3, half-maximal cytotoxic concentration: > 100000 nM
Compound 3 was reported as a limit (the forecaster's own chance of this, stated with the estimate: 85%); the middle value lies on the limit itself.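

Compound 1, compound 2 and compound 3 all read only as limits in this assay, so the steps from compound 2 to compound 3 and from compound 1 to compound 3 cannot be read: the limit of > 100000 nM in this assay, at which 3 of the 3 values shown sit.

The compounds shown leave open whether bromo or methyl on the aromatic ring changes cytotoxicity at all, and at what concentration any of them becomes toxic.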